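Chalcone amide series: Vero cytotoxicity outlook for compound 3

This account rests on a few compounds, and the source may have more. Where it says the series, first, only, none or still open, it means among the compounds named here.

Measured so far in an ADME assay on Vero cells (Chlorocebus sabaeus) for cytotoxicity, read by MTT assay, with a stated time of 72 h; on this read-out higher numbers stand for lower toxicity in this test and lower numbers for higher toxicity in this test:
compound 1 `COC(=O)c1cc(-c2cccc(NC(=O)c3ccc(/C=C/C(=O)c4ccc(OC)cc4)cc3)c2)on1`, > 10 ug/mL
compound 2 `COC(=O)c1cc(-c2cccc(NC(=O)c3ccc(/C=C/C(=O)c4ccc(C)c([N+](=O)[O-])c4)cc3)c2)on1`, > 80 ug/mL

In this assay compound 1 gives > 10 ug/mL, which is a limit of the assay. Compound 2 gives > 80 ug/mL, also a limit. The step that the two limits leave unreadable from compound 1 to compound 2 is therefore not readable in size, as both the limit of > 10 ug/mL in this assay, at which 1 of the 2 values shown sits, and the limit of > 80 ug/mL in this assay, at which 1 of the 2 values shown sits, show. Compound 2 stands at the higher of the two limits. Compound 3 `COC(=O)c1cc(-c2cccc(NC(=O)c3ccc(/C=C/C(=O)c4ccc(OC)c([N+](=O)[O-])c4)cc3)c2)on1` differs from compound 2 by methoxy in place of methyl on an aromatic carbon. Going by the values given here, no measured step bears on this change, and the one step recorded is unreadable, so no movement beyond the scatter is expected. Compound 3 is expected to give 80 ug/mL (40 ug/mL to 160 ug/mL), the expected step of a number no higher from compound 2 to compound 3 (the limit leaves the size open) lying within the scatter.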

Compound 3, half-maximal cytotoxic concentration: > 40 ug/mL
Compound 3 was reported as a limit (the forecaster's own chance of this, stated with the estimate: 70%); the middle value lies beyond the limit too.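

Compound 3 is reported only as a limit in this assay, so no step from compound 3 to compound 1 or compound 2 can be read: the limit of > 40 ug/mL in this assay, at which 1 of the 3 values shown sits.

From the compounds shown here alone, whether the methoxy, methyl and nitro changes shift cytotoxicity at all stays open.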